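Swapping the ether side chain for an acetamido group

The source may hold more compounds than are shown below. What is called first, only, known or untested is meant among the compounds shown, and "the series" means these compounds.

Measured compounds in an in vitro ADME assay on microsomes from liver (Homo sapiens) for metabolic stability, tested at 5 uM; on this read-out lower numbers stand for a shorter-lived compound and higher numbers for a longer-lived compound:
compound 1 `CC(C)CCn1nc(-c2cccs2)c(O)c(C2=NS(=O)(=O)c3cc(OCC(N)=O)ccc3N2)c1=O` gives 0.383 h;
compound 2 `CC(C)CCn1nc(-c2cccs2)c(O)c(C2=NS(=O)(=O)c3cc(OC(C)(C)C(N)=O)ccc3N2)c1=O` gives 0.35 h;
compound 3 `CCC(Oc1ccc2c(c1)S(=O)(=O)N=C(c1c(O)c(-c3cccs3)nn(CCC(C)C)c1=O)N2)C(N)=O` gives 0.35 h.

Compound 3 stands level with compound 2 at the digits shown, and these two are together the lowest of the three numbers. Its furthest neighbour is compound 1, and even that gap, a 1.1-fold lower number from compound 1 to compound 3 (0.04 log units; within the scatter), lies within the scatter. The other two steps, a 1.1-fold lower number from compound 1 to compound 2 (0.04 log units; within the scatter) and no change at the digits printed from compound 2 to compound 3 (within the scatter), are likewise within the scatter, so the three side chains on the oxygen on the aromatic ring are indistinguishable in this assay.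

Compound 4 `CC(=O)Nc1ccc2c(c1)S(=O)(=O)N=C(c1c(O)c(-c3cccs3)nn(CCC(C)C)c1=O)N2` changes that position in a different way: acetamido in place of 1-carbamoylpropoxy on an aromatic carbon. Among the compounds with values here, none of the measured steps removes the oxygen link itself, so they bear on this change only loosely. All three were within the scatter, and there is nothing in the measured numbers pointing to a step beyond it in either direction.

Compound 4 is therefore expected to give 0.35 h, with a range from 0.17 h to 0.7 h. The step of no change at the digits printed from compound 3 to compound 4 (within the scatter) is expected to stay within the scatter.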

Compound 4, half-life: 0.055 h
Estimate against measurement, compound 4: 6.4-fold (0.80 log units) above, and the stated range ends above it.
By their numbers in this assay, from the lowest: compound 4; then compounds 2, 3 and 1 (each within the scatter of the next).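

In this assay, the three ether side chains had left the number unmoved within the scatter, but this position is not indifferent to every change, as acetamido gives a drop beyond the scatter against each of them (a 6.4-fold lower number from compound 3 to compound 4 (0.80 log units; beyond the scatter); a 6.4-fold lower number from compound 2 to compound 4 (0.80 log units; beyond the scatter); a 7.0-fold lower number from compound 1 to compound 4 (0.84 log units; beyond the scatter)). Compound 4 is thus the shortest-lived of the four, and the similar size of the three steps shows that the outcome does not depend on which of the three ether side chains it is compared with. No measurement here explains why the half-life falls with this change.

The change replaces the oxygen link and the carbamoyl-bearing chain in one move, going from a group of 7 heavy atoms in 1-carbamoylpropoxy to one of 4 in acetamido, so the compounds shown do not separate the effect of the link from that of the group built on it. A methoxy group or a plain amine on the same aromatic carbon, or a longer chain on the amide carbonyl in place of the methyl of acetamido, would help to pull these contributions apart.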